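From compound 2 to its chloro analogue

The source may report more compounds than this note shows. Statements on the series, on what has been measured and on what is new or still open speak of the compounds shown alone.

- compound 1 `CC(C)(C)/N=c1\c(O)c(O)\c1=N/Cc1cccnc1`: 2600 nM
- compound 2 `CC(C)(C)/N=c1\c(O)c(O)\c1=N/Cc1ccccc1`: 3400 nM
- compound 3 `CC(C)(C)/N=c1\c(O)c(O)\c1=N/Cc1ccccc1F`: 2100 nM

In a functional assay for inhibition, with Rattus norvegicus as the target (on this read-out higher numbers stand for weaker inhibition and lower numbers for stronger inhibition), compound 2 gives 3400 nM, and this value lies within the scatter of those for compound 1 and compound 3. Compound 4 `CC(C)(C)/N=c1\c(O)c(O)\c1=N/Cc1ccc(Cl)cc1`, not yet measured, differs from compound 2 as follows: chloro in place of hydrogen on an aromatic carbon. This is chloro in place of hydrogen on an aromatic carbon. The closest guide is a fluoro replacing a hydrogen, which gave a 1.6-fold lower number from compound 2 to compound 3 (0.21 log units; within the scatter). Swapping the ring itself gave a 1.3-fold higher number from compound 1 to compound 2 (0.12 log units; within the scatter). Neither change moved the value beyond the scatter, so no step beyond the scatter is expected here. The expected change is a 1.4-fold lower number from compound 2 to compound 4 (0.13 log units; within the scatter). For compound 4 the estimated value is 2500 nM, with an expected range from 1100 nM to 5500 nM.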

Compound 4, half-maximal inhibitory concentration: 1700 nM
Compound 4: middle estimate off by 1.5-fold (0.17 log units), on the high side, and the stated range covers the measured number.
By their numbers in this assay, from the lowest: compounds 4, 3, 1 and 2 (each within the scatter of the next).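

Placing a chloro group on an aromatic carbon, para to a large group, gives a 2.0-fold lower number from compound 2 to compound 4 (0.30 log units; within the scatter) in this assay and so keeps the value within the usual scatter. This is the first compound shown with a substituent at this place on the ring, and the place accepts a chlorine atom without a step beyond the scatter. No available evidence explains this result. As far as these compounds go, whether a methoxy group, an amine or a carboxylic acid at the same place would also stay within the scatter remains open.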